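Swapping Bromo for Propyl on Two Inactive Anilides

The compounds below may be only part of what the source reports. "The series", "measured", "known", "first", "only" and "open" are said of these compounds alone.

Compound 1, `Nc1ccccc1NC(=O)c1ccc(COc2ccc([N+](=O)[O-])cc2)cc1`: > 32000 nM
Compound 2, `Nc1ccccc1NC(=O)c1ccc(COc2ccc(Br)cc2)cc1`: > 32000 nM

Both measured compounds were tested in a functional assay on HCT-116 cells (Homo sapiens) for antiproliferative activity, read by CCK-8 assay, with a stated time of 72 h; a lower number here means a stronger inhibitor, a higher number a weaker inhibitor. In this assay compound 1 gives > 32000 nM, which is a limit of the assay and not a number. Compound 2 gives > 32000 nM, again a limit rather than a number. Within the data shown here, the only computed step, a step that the two limits leave unreadable from compound 1 to compound 2, cannot be read because of the limit of > 32000 nM in this assay, at which 2 of the 2 values shown sit. Compound 3, `CCCc1ccc(OCc2ccc(C(=O)Nc3ccccc3N)cc2)cc1`, differs from compound 2 in one place: propyl in place of bromo on an aromatic carbon. No readable measured step bears on this change, since the single step shown is unreadable, so no direction can be drawn from the data; with compound 2 sitting at a limit, the most likely outcome is another limit. Compound 3 is therefore expected to give about 30000 nM, in the range 5000 nM to 100000 nM. The step of an at least 1.0-fold lower number from compound 2 to compound 3 (0.02 log units; that floor lies within the scatter) is an estimate only, not a measurement.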

Compound 3, half-maximal inhibitory concentration: 3230 nM
For compound 3 the middle estimate is 9.3-fold (0.97 log units) above the measured one, and the stated range ends above it.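

Among these compounds, on the aromatic carbon that carried the bromo group, the result gives the first readable change in this assay: propyl in place of bromo gives an at least 9.9-fold lower number from compound 2 to compound 3 (0.99 log units; beyond the scatter). Propyl in place of nitro gives an at least 9.9-fold lower number from compound 1 to compound 3 (0.99 log units; beyond the scatter). The step between the two earlier compounds cannot be read, so only now is it visible that the group at this place can shift the read-out, and that the propyl compound falls inside the measurable range.

As far as these compounds go, the full size of both steps stays unknown because their starting values are limits and not numbers: the limit of > 32000 nM in this assay, at which 2 of the 3 values shown sit. From the compounds shown here alone, it also remains open whether a longer chain such as butyl, or an amine or a carboxylic acid at this place, would lower the number further or raise it again.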